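A few compounds are considered here, and "the series" means these few. Any claim that something is new, unique, unknown or untested is made for them only; others in the source may bear on it.

Measured so far in a functional assay, read by MTT assay, with a stated time of 4 h; on this read-out higher numbers stand for weaker inhibition and lower numbers for stronger inhibition:
compound 1 `Oc1ccc(Cc2c(Br)c(O)c(O)c(O)c2Br)cc1O` gives 84200 nM
compound 2 `Oc1cc(Cc2ccccc2)c(Br)c(Br)c1O` gives 88000 nM

The two numbers of compound 1 and compound 2 lie within the usual scatter of each other, so compound 2 does not stand apart from compound 1 on this read-out; both are weak inhibitors in this assay.

Compound 3 `Oc1cc(Br)c(Cc2ccccc2)cc1O` differs from compound 2 in one place: hydrogen in place of bromo on an aromatic carbon. Going by the values given here, no pair of measured compounds differing in one place exists, so there is no measured step to set the size of this change. Given that compound 2 sits at 88000 nM and compound 1 at a number within the scatter of it, the step is expected to be small, at most a drift toward weaker inhibition, and is estimated at a 1.1-fold higher number from compound 2 to compound 3 (0.06 log units; within the scatter). Compound 3 is therefore expected to give about 100000 nM in this assay, with a range from 40000 nM to 250000 nM.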

Compound 3, half-maximal inhibitory concentration: 164000 nM
The estimate for compound 3 lay 1.6-fold (0.21 log units) below the measured number; low and high end bracket the measured number.
By their numbers in this assay, from the lowest: compounds 1, 2 and 3 (each within the scatter of the next).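

In this assay, hydrogen in place of bromo on an aromatic carbon ortho to a bromo group and ortho to a hydroxy group gives a 1.9-fold higher number from compound 2 to compound 3 (0.27 log units; within the scatter) for this single change. Going by these compounds alone, this is the first step that can be read at one place, and it shows that this bromo group can give way to hydrogen with no change beyond the scatter on this read-out. No supporting measurement bears on this result, so the step stands without an explanation.

Open, going by these compounds, is whether a group other than bromo or hydrogen on this aromatic carbon, such as an amine, a carboxylic acid or a methoxy group, would give a step beyond the scatter. Also open, on these data alone, is how a change at the remaining bromo group or at either hydroxy group would read in this assay on the same core.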